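Trimming the amide cap of a T-cell inhibitor

The compounds below may be only part of what the source reports. "The series", "measured", "known", "first", "only" and "open" are said of these compounds alone.

Compound 1 `COc1ccc(-c2cnc3nc(N)nc(N4CCN(C(=O)NCc5ccc(F)cc5)CC4)c3n2)cc1OC` carries a (4-fluorobenzyl)carbamoyl arm on its shared core. In a functional assay on cells (T-cell, Homo sapiens) for inhibition (a lower number here means a stronger inhibitor, a higher number a weaker inhibitor), compound 1 gives 37 nM, the lowest of the two numbers recorded here. Its nearest neighbour is compound 3 `COc1ccc(-c2cnc3nc(N)nc(NC4CCCC4)c3n2)cc1OC`, which gives 800 nM in this assay, a gap that lies beyond the scatter. Compound 2 `CC(C)Oc1nc(N)nc2ncc(-c3ccc(C#N)cc3)nc12` is reported only as a limit of this assay, > 10000 nM; this is the limit of > 10000 nM in this assay, at which 1 of the 3 values shown sits. Compound 4 `COc1ccc(-c2cnc3nc(N)nc(N4CCN(C(=O)Nc5ccccc5)CC4)c3n2)cc1OC` has not yet been measured in this assay. It differs from compound 1 in one place: phenyl in place of 4-fluorobenzyl on an amide-type nitrogen. Among the compounds with values here, no pair of measured compounds differs by this kind of change, so there is no measured step to lean on. The amide-type nitrogen and the rest of compound 1, which gives 37 nM, stay intact, and only the group on that nitrogen is exchanged. The author expects a modest move toward a higher number, in the step of a 2.2-fold higher number from compound 1 to compound 4 (0.33 log units; beyond the scatter). Compound 4 is therefore estimated at 80 nM, with a range from 20 nM to 400 nM.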

Compound 4, half-maximal inhibitory concentration: 3.4 nM
Compound 4: the middle estimate sits 24-fold (1.37 log units) above what was measured; measured number outside the range, below it.
By their numbers in this assay, from the lowest: compound 4; then compound 1; then compound 3. At a limit, above all of these: compound 2.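

Within the data shown here, exchanging 4-fluorobenzyl for phenyl on the amide-type nitrogen gives an 11-fold lower number from compound 1 to compound 4 (1.04 log units; beyond the scatter) in this assay, the first reading of how strongly this position responds, since the earlier compounds offered no step here. The change takes away the carbon link and the fluorine together, and the result shows only that the smaller phenyl cap is well accepted on this arm, not which of the two losses matters. No measurement shown here bears on why the step is so large.

Benzyl and 4-fluorophenyl on the same nitrogen would separate the two losses, and they are absent from the compounds shown. Also open, as far as these compounds go, is how this position responds to a group that is not a plain aromatic ring, such as cyclohexyl, or to a longer chain such as 2-phenylethyl.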